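Dimethoxyphenyl Variant Expected to Stay at the Ceiling

The source may hold more compounds than are shown below. What is called first, only, known or untested is meant among the compounds shown, and "the series" means these compounds.

Compound 1 `COc1ccccc1-n1nncc1CN1C(=O)C2(C(C#N)=C(N)Oc3c2c2nc4ccccc4nc2c2ccccc32)c2ccccc21`: in an ADME assay on L02 cells (Homo sapiens) for antiproliferative activity, read by MTT assay, with a stated time of 48 h (on this read-out lower numbers stand for stronger inhibition and higher numbers for weaker inhibition), compound 1 reaches only the limit > 50000 nM.
Compound 2 `Cc1ccccc1-n1nncc1CN1C(=O)C2(C(C#N)=C(N)Oc3c(N)cc4nc5ccccc5nc4c32)c2ccccc21`: in this assay compound 2 likewise gives only the limit > 50000 nM.

Among the compounds with values here, compound 2 thus stands at the ceiling of this assay with no number of its own, and the one other value shown sits at the same place, as the limit of > 50000 nM in this assay, at which 2 of the 2 values shown sit, records. Compound 3 `COc1ccc(OC)c(-n2nncc2CN2C(=O)C3(C(C#N)=C(N)Oc4c(N)cc5nc6ccccc6nc5c43)c3ccccc32)c1` differs from compound 2 by 2,5-dimethoxyphenyl in place of 2-methylphenyl on an aromatic nitrogen. Within the data shown here, no step between measured compounds is available, so no direction can be drawn from the data. The expectation is that compound 3 also stays at the ceiling, the step of a number no higher from compound 2 to compound 3 (the limit leaves the size open) being reckoned as none beyond the scatter. Compound 3 is accordingly estimated at 50000 nM, within 20000 nM to 120000 nM, and most likely reported as a limit again.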

Compound 3, half-maximal inhibitory concentration: > 50000 nM
Compound 3 was reported as a limit; the forecaster's own chance of this, stated with the estimate: 75%; the middle value sits exactly at the limit.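

In this assay compound 2 and compound 3 both give limits, not numbers, and no step can be read between them. The compounds shown leave open what concentration lies behind each limit and whether the aryl group on the nitrogen matters at all.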